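This account rests on a few compounds, and the source may have more. Where it says the series, first, only, none or still open, it means among the compounds named here.

Measured so far in a functional assay on WiDr cells (Homo sapiens) for antiproliferative activity, read by sulforhodamine B assay, with a stated time of 48 h; on this read-out lower numbers stand for stronger inhibition of growth and higher numbers for weaker inhibition of growth:
- compound 1, `Cc1ccc(S(=O)(=O)N2CCC(Cl)CC2)cc1`, gives > 100000 nM; that value is a limit of the assay.
- compound 2, `Cc1ccc(S(=O)(=O)N2CC[C@@H](Cl)C[C@@H]2CC(C)C)cc1`, gives 22000 nM.
- compound 3, `CCCCCCC[C@H]1C[C@H](Cl)CCN1S(=O)(=O)c1ccc(C)cc1`, gives 54000 nM.

Compound 3 stands highest of the two numbers in this assay; the nearest is compound 2, and the step of a 2.5-fold higher number from compound 2 to compound 3 (0.39 log units; beyond the scatter) lies beyond the scatter. For compound 1 only the limit of > 100000 nM in this assay, at which 1 of the 3 values shown sits, is known. Against that limit the step of an at least 4.5-fold lower number from compound 1 to compound 2 (0.65 log units; beyond the scatter) is at least modest, while the step of an at least 1.8-fold lower number from compound 1 to compound 3 (0.26 log units; that floor lies within the scatter) has a floor that still lies within the scatter.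

Compound 4, `Cc1ccc(S(=O)(=O)N2CC[C@@H](Cl)C[C@@H]2C2CCCCC2)cc1`, differs from compound 3 by cyclohexyl in place of heptyl on a saturated ring carbon. The step that bears on this change is the one comparing two different substituents at this ring carbon, a 2.5-fold higher number from compound 2 to compound 3 (0.39 log units; beyond the scatter), in which hexyl in place of isopropyl gave a modestly higher number. Compound 4 brings a group of a size between the isobutyl of compound 2 and the heptyl of compound 3, so a modest step downward in this assay, or none beyond the scatter, is expected. Compound 4 is therefore estimated at 30000 nM, with a range from 10000 nM to 90000 nM. That estimate corresponds to an expected step of a 1.8-fold lower number from compound 3 to compound 4 (0.26 log units; within the scatter).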

Compound 4, concentration for 50% growth inhibition: 15000 nM
Compound 4: middle estimate off by 2.0-fold (0.30 log units), on the high side; the range from low to high includes it.
By their numbers in this assay, from the lowest: compounds 4 and 2 (each within the scatter of the next); then compound 3. At a limit, above all of these: compound 1.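

In this assay, the change from heptyl to cyclohexyl on the saturated ring carbon next to the ring nitrogen gives a 3.6-fold lower number from compound 3 to compound 4 (0.56 log units; beyond the scatter), so the result at this position depends on which group is present, not merely on a large group being there. With a 1.5-fold lower number from compound 2 to compound 4 (0.17 log units; within the scatter), cyclohexyl and isobutyl cannot be told apart, and among the substituted compounds only the heptyl of compound 3 stands apart from the other two. The gain over the hydrogen of compound 1, an at least 6.6-fold lower number from compound 1 to compound 4 (0.82 log units; beyond the scatter), is only a floor, since compound 1 sits at a limit of the assay: the limit of > 100000 nM in this assay, at which 1 of the 4 values shown sits.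

The compounds shown leave open whether the step from heptyl depends on the ring itself or on chain length, a question that a straight butyl or a phenyl at this carbon would help to separate. Also open, going by these compounds, is whether a cyclohexyl bearing an amine or a carboxylic acid would keep the number of compound 4, and how much the chloro group contributes to any of these steps.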